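A few compounds are considered here, and "the series" means these few. Any claim that something is new, unique, unknown or untested is made for them only; others in the source may bear on it.

Measured compounds in a functional assay on the whole organism for inhibition, with Mus musculus as the target, at a dose of 25 mg/kg by the oral route; on this read-out lower numbers stand for less inhibition and higher numbers for more inhibition at the one dose given (going by the name of the read-out):
compound 1 `c1ccc(N2CCN(CCCCOc3ccc4c(c3)CCC4)CC2)cc1`, 50%
compound 2 `Clc1ccc(N2CCN(CCCCOc3ccc4c(c3)CCC4)CC2)cc1`, 33%

Compound 2 stands lowest of the two numbers; its nearest neighbour is compound 1, which in this assay gives 50%. Among the compounds with values here, the one step between them, a number 17 percentage points lower from compound 1 to compound 2 (beyond the scatter), is the only measured step.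

Compound 3 `COc1ccccc1N1CCN(CCCCOc2ccc3c(c2)CCC3)CC1` is not yet measured in this assay. Relative to compound 2 the change is 2-methoxyphenyl in place of 4-chlorophenyl on an amine nitrogen in a ring. The step from compound 1 to compound 2 bears on it in part: it shows what the chlorine adds, and compound 3 takes that chlorine away, so a move back toward the value of compound 1 is expected. Within the data shown here, for the methoxy group that enters there is no measured step, so no reasonable size can be assigned to it beyond this. Among the measured compounds shown here, the expected step of a number 15 percentage points higher from compound 2 to compound 3 (beyond the scatter) is therefore a modest rise of about the size of the one measured step, with wide uncertainty. Compound 3 is estimated to give 48%, with a range from 30% to 66%.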

Compound 3, a percentage reported as inhibition, in the whole organism at one dose (the size of the read-out at that dose, not a potency): 42%
Compound 3: the middle estimate sits 6 percentage points above what was measured; the range from low to high includes it.
By their numbers in this assay, from the lowest: compounds 2, 3 and 1 (each within the scatter of the next, the first and the last beyond it).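

In this assay, the exchange of 4-chlorophenyl for 2-methoxyphenyl gives a number 9 percentage points higher from compound 2 to compound 3 (within the scatter), while methoxy in place of hydrogen gives a number 8 percentage points lower from compound 1 to compound 3 (within the scatter), so compound 3 cannot be told apart from either neighbour, although those two neighbours are separated by a number 17 percentage points lower from compound 1 to compound 2 (beyond the scatter). A substituent on this aryl group therefore does not always carry a step beyond the scatter: chloro does in compound 2 and methoxy does not in compound 3, but these two compounds differ in both the group and its place on the ring, so the comparison cannot assign the outcome to either one. No available evidence bears on the reason for these numbers.

The compounds shown leave open how much the group and its place each count, which 2-chlorophenyl or 4-methoxyphenyl on the same amine nitrogen would separate. They also leave open whether a pyridyl ring in place of the phenyl, or a longer chain in the core of compound 1, would move the number beyond the scatter, and with a single dose they say nothing about potency.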